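The source may hold more compounds than are shown below. What is called first, only, known or untested is meant among the compounds shown, and "the series" means these compounds.

Three compounds have so far been measured in a functional assay on HL-60 cells (Homo sapiens) for inhibition, read by XTT assay, with a stated time of 72 h; on this read-out lower numbers stand for stronger inhibition and higher numbers for weaker inhibition:

Compound 1, `[N-]=[N+]=NCc1ncnc2c1ncn2[C@@H]1O[C@H](CO)[C@@H](O)[C@H]1O`, gives 780 nM.
Compound 2, `OC[C@H]1O[C@@H](n2cnc3c(COc4ccccn4)ncnc32)[C@H](O)[C@@H]1O`, gives 14300 nM.
Compound 3, `CN(Cc1ccccc1)Cc1ncnc2c1ncn2[C@@H]1O[C@H](CO)[C@@H](O)[C@H]1O`, gives 2400 nM.

Compound 1 has the lowest number of the three, and both changes made at its azido group raised the number: an 18-fold higher number from compound 1 to compound 2 (1.26 log units; beyond the scatter) and a 3.1-fold higher number from compound 1 to compound 3 (0.49 log units; beyond the scatter). Compound 4, `COCc1ncnc2c1ncn2[C@@H]1O[C@H](CO)[C@@H](O)[C@H]1O`, keeps the shared core and differs from compound 1 only in that (methoxy in place of azido on a saturated chain carbon bound to an aromatic carbon). The two measured steps bear on this one, since each likewise replaced the azido group at the same place and each gave a higher number; the smaller of the two entering groups gave the smaller rise. Methoxy is a group of fewer heavy atoms than either, so a rise of about the smaller kind is expected for compound 4, estimated as 1500 nM, ranging from 500 nM to 5000 nM, which would mean a 1.9-fold higher number from compound 1 to compound 4 (0.28 log units; within the scatter).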

Compound 4, half-maximal inhibitory concentration: 1680 nM
For compound 4 the middle estimate is 1.1-fold (0.05 log units) below the measured one; low and high end bracket the measured number.
By their numbers in this assay, from the lowest: compound 1; then compounds 4 and 3 (each within the scatter of the next); then compound 2.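

At this place, on a saturated chain carbon bound to an aromatic carbon, even the small methoxy group gives up some of the inhibition seen with azido in this assay (a 2.2-fold higher number from compound 1 to compound 4 (0.33 log units; beyond the scatter)). The size of the entering group does not by itself set the number: methoxy and the much larger benzyl(methyl)amino stand level (a 1.4-fold lower number from compound 3 to compound 4 (0.15 log units; within the scatter)), whereas methyl in place of pyridin-2-yl on the oxygen gives a clear change (an 8.5-fold lower number from compound 2 to compound 4 (0.93 log units; beyond the scatter)). No evidence on the reason for these differences is at hand. From the compounds shown here alone, whether a primary amine or a longer ether chain here would match azido remains open.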